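The source may report more compounds than this note shows. Statements on the series, on what has been measured and on what is new or still open speak of the compounds shown alone.

Among the compounds with values here, in a functional assay on A549 cells (Homo sapiens) for inhibition (on this read-out lower numbers stand for stronger inhibition and higher numbers for weaker inhibition), compound 2 (`CCCCCOC(=O)Nc1nc(=O)n(C2O[C@H](C(=O)O)[C@@H](O)[C@H]2O)cc1F`) gives 0.17 ug/mL, the lower of the two numbers so far, while compound 1 (`CCOC(=O)Nc1nc(=O)n(C2O[C@H](C(=O)O)[C@@H](O)[C@H]2O)cc1F`) gives 0.49 ug/mL. Compound 3 (`O=C(Nc1nc(=O)n(C2O[C@H](C(=O)O)[C@@H](O)[C@H]2O)cc1F)OCc1ccccc1`) is still unmeasured. The change is phenyl in place of butyl on a saturated chain carbon bound to an oxygen next to a carbonyl group, which turns pentyloxy into benzyloxy. Within the data shown here, only one measured step bears on this, a 2.9-fold lower number from compound 1 to compound 2 (0.46 log units; beyond the scatter), a modest change beyond the scatter that comes from extending the chain. Among the measured compounds shown here, no measured compound carries a ring in this group, so that step is only a loose guide. No step beyond the scatter is expected in this assay, with any drift towards a higher number. The expected change is a 1.5-fold higher number from compound 2 to compound 3 (0.17 log units; within the scatter). Compound 3 is estimated at 0.25 ug/mL, with an expected range of 0.1 ug/mL to 0.6 ug/mL.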

Compound 3, half-maximal inhibitory concentration: 0.37 ug/mL
Compound 3: the middle estimate sits 1.5-fold (0.17 log units) below what was measured, within the range that was stated.
By their numbers in this assay, from the lowest: compound 2; then compounds 3 and 1 (each within the scatter of the next).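

At this saturated chain carbon bound to an oxygen next to a carbonyl group, an aromatic ring does not match the pentyl chain in this assay: phenyl in place of butyl gives a 2.2-fold higher number from compound 2 to compound 3 (0.34 log units; beyond the scatter), a modest step. Phenyl in place of methyl gives a 1.3-fold lower number from compound 1 to compound 3 (0.12 log units; within the scatter), so compound 3 cannot be told apart from compound 1, and a ring is accepted here without a step beyond the scatter from that compound. No measurement at hand accounts for either step.

Going by these compounds, whether a longer chain such as heptyl would extend the step seen with compound 2 stays open, as does how a saturated cyclohexyl ring would compare with phenyl at this carbon. Whether an amine on the phenyl ring would shift the number is equally unknown.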